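Aryl-for-furan exchange and cell growth inhibition

This account rests on a few compounds, and the source may have more. Where it says the series, first, only, none or still open, it means among the compounds named here.

The measured compounds:
compound 1 `Cc1ccc(Nc2ncc(Cl)c(Nc3ccccc3C)n2)cc1`, in an ADME assay on L02 cells (Homo sapiens) for inhibition, read by CCK-8 assay, with a stated time of 48 h (on this read-out higher numbers stand for weaker inhibition of growth and lower numbers for stronger inhibition of growth), compound 1 gives > 100000 nM, a limit of the assay.
compound 2 `Cc1ccccc1Nc1nc(NCc2ccco2)ncc1Cl`, in this assay compound 2 gives > 100000 nM, also a limit.
compound 3 `CN1CCN(c2ccc(Nc3ncc(Cl)c(NCc4ccco4)n3)nc2)CC1`, in this assay compound 3 gives 45700 nM.

Among the measured compounds shown here, compound 3 carries the only number in the set; the other two values are limits. The step that the two limits leave unreadable from compound 2 to compound 1 cannot be read because of the limit of > 100000 nM in this assay, at which 2 of the 3 values shown sit. The change behind it is 4-methylphenyl in place of (furan-2-yl)methyl on a nitrogen on an aromatic ring.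

Compound 4 `Cc1ccc(Nc2nc(Nc3ccc(N4CCN(C)CC4)cn3)ncc2Cl)cc1` is not yet measured. It is reached from compound 3 by 4-methylphenyl in place of (furan-2-yl)methyl on a nitrogen on an aromatic ring, and the place lines of the two changes agree word for word, so this is the same change as from compound 2 to compound 1. The difference between the core of compound 3 and the core of compound 2 is not broken down here.

Since the earlier step could not be read, the step of a 1.3-fold higher number from compound 3 to compound 4 (0.12 log units; within the scatter) in this assay is an expectation with little support, set near no change. Compound 4 is expected at 60000 nM, between 20000 nM and 200000 nM.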

Compound 4, concentration for 50% growth inhibition: 13900 nM
Compound 4: middle estimate off by 4.3-fold (0.64 log units), on the high side; measured number outside the range, below it.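

In this assay, 4-methylphenyl in place of (furan-2-yl)methyl on a nitrogen on an aromatic ring gives a 3.3-fold lower number from compound 3 to compound 4 (0.52 log units; beyond the scatter), so on the core of compound 3 this change goes with stronger inhibition of growth. The same change on the core of compound 2 gives no size that could be set beside it, because the step from compound 2 to compound 1 cannot be read: the limit of > 100000 nM in this assay, at which 2 of the 4 values shown sit. The series therefore offers one readable step on one core, which shows what the change does there but does not show whether it carries from one core to another.

The compounds shown leave open whether the step follows from the new ring or from the loss of the carbon that joins the furan to the nitrogen, a question that a benzyl group on the same nitrogen would address. They also leave open how the core of compound 4 responds when a carboxylic acid or a primary amine stands on that phenyl ring in place of the methyl.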